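This account rests on a few compounds, and the source may have more. Where it says the series, first, only, none or still open, it means among the compounds named here.

Measured in a functional assay on THP-1 cells (Homo sapiens) for cytotoxicity, read by MTT assay, with a stated time of 24 h; a higher number here means a weaker inhibitor, a lower number a stronger inhibitor:
- Compound 1 `COc1ccc(/C=C2\CN(C)C/C(=C\c3ccccc3F)C2=O)cc1` gives 15400 nM
- Compound 2 `CN1C/C(=C\c2ccc(C(F)(F)F)cc2)C(=O)/C(=C/c2ccccc2F)C1` gives 5930 nM
- Compound 3 `CN1C/C(=C\c2ccc(C#N)cc2)C(=O)/C(=C/c2ccccc2F)C1` gives 810 nM

Compound 3 stands lowest of the three in this assay with 810 nM as its number. Compound 4 `CN1C/C(=C\c2ccc(Cl)cc2)C(=O)/C(=C/c2ccc(C#N)cc2)C1` keeps the cyano group of compound 3 and changes elsewhere: 4-chlorophenyl in place of 2-fluorophenyl on a double-bonded chain carbon bound to a double-bonded ring carbon. The measured steps, modest to large, all concern the other aromatic group: a 2.6-fold lower number from compound 1 to compound 2 (0.41 log units; beyond the scatter), a 19-fold lower number from compound 1 to compound 3 (1.28 log units; beyond the scatter) and a 7.3-fold lower number from compound 2 to compound 3 (0.86 log units; beyond the scatter). None of them tests the place that changes here, so they set no direction. A shift beyond the scatter is therefore not expected, though the uncertainty is wide. The expected step is a 1.1-fold higher number from compound 3 to compound 4 (0.05 log units; within the scatter) in this assay. For compound 4 the estimated value is 900 nM with an expected range from 280 nM to 2900 nM.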

Compound 4, half-maximal inhibitory concentration: 3180 nM
Compound 4: middle estimate off by 3.5-fold (0.55 log units), on the low side, and the stated range ends below it.
By their numbers in this assay, from the lowest: compound 3; then compounds 4 and 2 (each within the scatter of the next); then compound 1.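

In this assay, going by these compounds alone, the group on the double-bonded chain carbon bound to a double-bonded ring carbon proves to matter, which the earlier compounds, all sharing 2-fluorophenyl there, could not show: 4-chlorophenyl in its place gives a 3.9-fold higher number from compound 3 to compound 4 (0.59 log units; beyond the scatter) with the cyano-bearing group held fixed. This position therefore moves the number beyond the scatter, here towards weaker inhibition. No measurement at hand explains the shift. The compounds shown leave open whether the identity of the halogen or its place on the ring carries the step, and how 4-fluorophenyl, 2-chlorophenyl or a phenyl bearing an amine would behave here.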